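Widening the Nitrogen Substituent from Methyl to Isopropyl

The source may report more compounds than this note shows. Statements on the series, on what has been measured and on what is new or still open speak of the compounds shown alone.

Compound 1 `CCOc1ccc(-c2cc3c(cn2)[nH]c(=O)n3-c2cc(OC)c(OC)c(OC)c2)cc1F`: 2870 nM
Compound 2 `COc1ccc(-c2cc3c(cn2)[nH]c(=O)n3-c2cc(OC)c(OC)c(OC)c2)cc1C`: 1410 nM
Compound 3 `COc1ccc(-c2cc3c(cn2)n(C)c(=O)n3-c2cc(OC)c(OC)c(OC)c2)cc1O`: 2220 nM

In a functional assay on HeLa cells (Homo sapiens) for antiproliferative activity, read by MTT assay, with a stated time of 48 h (on this read-out lower numbers stand for stronger inhibition and higher numbers for weaker inhibition), compound 3 gives 2220 nM. This value lies within the usual scatter of the values of both compound 1 and compound 2, so compound 3 cannot be ranked against either of them. The next structure, compound 4 `COc1ccc(-c2cc3c(cn2)n(C(C)C)c(=O)n3-c2cc(OC)c(OC)c(OC)c2)cc1O`, has isopropyl in place of methyl on an aromatic nitrogen of the five-membered ring: isopropyl in place of methyl on an aromatic nitrogen.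

Within the data shown here, only one measured step exists in this small set, a 2.0-fold lower number from compound 1 to compound 2 (0.31 log units; beyond the scatter). It is modest, but it concerns a change of 4-ethoxy-3-fluorophenyl to 4-methoxy-3-methylphenyl on an aromatic carbon, so it bears only indirectly on the nitrogen. Compound 1 and compound 2 carry no carbon group on that nitrogen, and they also differ from compound 3 in the group on the aromatic carbon. No measurement therefore isolates a change at this nitrogen. Among the measured compounds shown here, the modest size of the one measured step suggests no large shift in this assay, and no direction is firmly supported. The expected change is a 1.3-fold higher number from compound 3 to compound 4 (0.10 log units; within the scatter), which would not stand beyond the scatter. Compound 4 is estimated at 2800 nM, with an expected range from 900 nM to 8000 nM.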

Compound 4, half-maximal inhibitory concentration: 4240 nM
Beside the measured number, compound 4's estimate is 1.5-fold (0.18 log units) below it; low and high end bracket the measured number.
By their numbers in this assay, from the lowest: compounds 2, 3, 1 and 4 (each within the scatter of the next, the first and the last beyond it).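

Among these compounds, compound 3 and compound 4 give the first comparison at this nitrogen with the rest of the structure held fixed, which the earlier compounds could not give, as those with a hydrogen on that nitrogen also differ in the group on the aromatic carbon. In this assay the exchange of methyl for isopropyl is a 1.9-fold higher number from compound 3 to compound 4 (0.28 log units; within the scatter) and therefore does not separate the two groups, so the measurements show no reliable effect of widening this substituent from methyl to isopropyl. No measured information is available that could account for this outcome.

The compounds shown leave open how the nitrogen would respond to groups of other kinds, such as a longer chain like n-butyl, a cyclopropyl ring or a chain ending in an amine or a carboxylic acid, and what a plain hydrogen there would give with the rest of compound 3 unchanged. They also leave open whether the same exchange would read alike on the other aromatic groups carried by compound 1 and compound 2.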